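Amide tail variation on the shared core

The source may hold more compounds than are shown below. What is called first, only, known or untested is meant among the compounds shown, and "the series" means these compounds.

Compound 3 `COc1cc(-c2nn(-c3cccc(NC(=O)Nc4ccc(Cl)c(C(F)(F)F)c4)c3)cc2-c2ccncc2)ccc1Cl` gives 1040 nM in a functional assay on NCI/ADR-RES cells (Homo sapiens) for inhibition, read by sulforhodamine B assay, with a stated time of 48 h; a higher number here means a weaker inhibitor of growth, a lower number a stronger inhibitor of growth; compound 1 `COc1cc(-c2nn(-c3cccc(NC(=O)c4cccc(C(F)(F)F)c4)c3)cc2-c2ccncc2)ccc1Cl` gives 1090 nM and compound 2 `COc1cc(-c2nn(-c3cccc(NC(=O)c4ccc(Cl)c(C(F)(F)F)c4)c3)cc2-c2ccncc2)ccc1Cl` gives 1290 nM, all three within the scatter of one another. Compound 4 `COc1cc(-c2nn(-c3cccc(NC(=O)c4ccccc4)c3)cc2-c2ccncc2)ccc1Cl` differs from compound 3 by phenyl in place of (4-chloro-3-(trifluoromethyl)phenyl)amino on a carbonyl carbon. For the measured compounds named here, two measured steps bear on this change: a 1.0-fold lower number from compound 1 to compound 3 (0.02 log units; within the scatter) and a 1.2-fold lower number from compound 2 to compound 3 (0.09 log units; within the scatter), both within the scatter, so exchanging the arylamino attachment for an aryl bonded straight to the carbonyl left this assay unchanged. The step of a 1.2-fold higher number from compound 1 to compound 2 (0.07 log units; within the scatter) shows the chloro addition also within the scatter. Going by the values given here, no measured step covers loss of the trifluoromethyl group. The expected step is a 1.4-fold higher number from compound 3 to compound 4 (0.16 log units; within the scatter), none beyond the scatter. For compound 4 the estimate is 1500 nM, with a range from 600 nM to 4000 nM.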

Compound 4, concentration for 50% growth inhibition: 448 nM
For compound 4 the middle estimate is 3.3-fold (0.52 log units) above the measured one; measured number below the stated range.
By their numbers in this assay, from the lowest: compound 4; then compounds 3, 1 and 2 (each within the scatter of the next).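

In this assay, for the compounds shown here, compound 4 is the first compound to separate from the others, with phenyl on the carbonyl carbon: a 2.3-fold lower number from compound 3 to compound 4 (0.37 log units; beyond the scatter) and a 2.9-fold lower number from compound 2 to compound 4 (0.46 log units; beyond the scatter), both modest but beyond the scatter. Going by these compounds alone, the cleanest reading is a 2.4-fold lower number from compound 1 to compound 4 (0.39 log units; beyond the scatter), where hydrogen in place of trifluoromethyl on an aromatic carbon is the only change, and the earlier compounds covered no such step. No available evidence explains this shift. Still open, as far as these compounds go, is whether a methyl group or a carboxylic acid in place of that trifluoromethyl would keep the lower number of compound 4.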